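A few compounds are considered here, and "the series" means these few. Any claim that something is new, unique, unknown or untested is made for them only; others in the source may bear on it.

Measured compounds in a functional assay on PC-12 cells (Rattus norvegicus) for cytotoxicity, read by MTT assay, with stated times of 2 h and 24 h, tested at 1 uM; a higher number here means a stronger effect of the compound at the concentration tested, a lower number a weaker effect:
- compound 1, `COc1ccc(-n2nc(-c3ccc(C(F)(F)F)cc3O)nc2-c2ccccc2O)cc1`, giving 69%
- compound 2, `Oc1cc(C(F)(F)F)ccc1-c1nc(-c2ccccc2O)n(-c2cccc(Cl)c2)n1`, giving 72.3%
- compound 3, `COc1cccc(-n2nc(-c3ccc(C(F)(F)F)cc3O)nc2-c2ccccc2O)c1`, giving 68.3%

Compound 3 sits at the lower end of these three numbers, yet its separation from compound 1 is a number 0.7 percentage points lower from compound 1 to compound 3 (within the scatter) and from compound 2 is a number 4 percentage points lower from compound 2 to compound 3 (within the scatter), so the three cannot be told apart in this assay.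

Compound 4, `Cc1ccc(-n2nc(-c3ccc(C(F)(F)F)cc3O)nc2-c2ccccc2O)c(C)c1`, is the next member. It differs from compound 3 by 2,4-dimethylphenyl in place of 3-methoxyphenyl on an aromatic nitrogen.

Going by the values given here, the steps that bear on this are the earlier exchanges of the aryl group on the same aromatic nitrogen: a number 3.3 percentage points higher from compound 1 to compound 2 (within the scatter) and a number 0.7 percentage points lower from compound 1 to compound 3 (within the scatter), both flat. Nothing in the series suggests that this position moves this assay, so no step beyond the scatter is expected: a number 0.7 percentage points higher from compound 3 to compound 4 (within the scatter). Compound 4 is therefore estimated at 69%, with a range from 60% to 78%.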

Compound 4, a percentage reported as activity, at one concentration (the size of the read-out at that concentration, not a potency): 73.7%
Beside the measured number, compound 4's estimate is 4.7 percentage points below it; the range from low to high includes it.
By their numbers in this assay, from the lowest: compounds 3, 1, 2 and 4 (each within the scatter of the next).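

In this assay the change to 2,4-dimethylphenyl on the aromatic nitrogen gives a number 5.4 percentage points higher from compound 3 to compound 4 (within the scatter) and a number 1.4 percentage points higher from compound 2 to compound 4 (within the scatter) and also a number 4.7 percentage points higher from compound 1 to compound 4 (within the scatter) with all three steps flat. The position therefore tolerates an aryl group of carbon only, carrying two methyl groups, without a step beyond the scatter, which the singly substituted chloro and methoxy aryl groups could not show. No evidence is available to account for this flat result. Still open, from the compounds shown here alone, is whether an amine or a carboxylic acid on this aryl ring would move the read-out. Going by these compounds, a longer alkyl chain in place of the aryl ring is equally open.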